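From Compound 2 to Compound 3: Methoxy Replaced

The source may hold more compounds than are shown below. What is called first, only, known or untested is meant among the compounds shown, and "the series" means these compounds.

Going by the values given here, only two compounds have been measured so far in a physicochemical assay for solubility, in phosphate buffer, at pH 7.4 (a lower number here means a less soluble compound, a higher number a more soluble compound), compound 1 `COC(=O)CNC(=O)NC1CCCCC1` and compound 2 `COC(=O)CCCCCNC(=O)NC1CCCCC1`. Compound 1 gives > 500000 nM, which is a limit of the assay and not a number. Compound 2 gives > 500000 nM, which is also a limit and not a number. Compound 2 thus has no exact figure, and the evidence amounts to the limit of > 500000 nM in this assay, at which 2 of the 2 values shown sit.

Compound 3 `CC(C)[C@H](NC(=O)CCCCCNC(=O)NC1CCCCC1)C(=O)O` differs from compound 2 in one place, with (1-carboxy-2-methylpropyl)amino in place of methoxy on a carbonyl carbon. Among the compounds with values here, no measured step is available to size this change. Resting on compound 2 at > 500000 nM, the expectation in this assay is for no step beyond the usual scatter, in either direction. The estimated step is a number no higher from compound 2 to compound 3 (the limit leaves the size open). For compound 3 the expected value is 500000 nM, with an estimated range from 200000 nM to 800000 nM.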

Compound 3, solubility: > 500000 nM
Compound 3: only a limit was reported (the forecaster's own chance of this, stated with the estimate: 75%); the middle value lies on the limit itself.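

Compound 2 and compound 3 both give only a limit in this assay, and the step between them cannot be read. The compounds shown leave open how far any of them lies past that limit, and whether they differ at all: the limit of > 500000 nM in this assay, at which 3 of the 3 values shown sit.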